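Cyclopentyl step repeated on a second core

A few compounds are considered here, and "the series" means these few. Any claim that something is new, unique, unknown or untested is made for them only; others in the source may bear on it.

Measured so far, with the largest response reached:
- compound 1, `COc1ccc(C(=O)O)cc1OCCCCOc1ccc(C(=O)CC2CCCC2)c(O)c1C`: 67.6%
- compound 2, `COc1ccc(C(=O)O)cc1OCCCCOc1ccc(C(C)=O)c(O)c1C`: 34.8%
- compound 3, `CC(=O)c1ccc(OCCCCOc2ccc(C(=O)O)cc2C)c(C)c1O`: 25.4%

In an assay on HEK293 cells for positive allosteric modulation of metabotropic glutamate receptor 3 (Rattus norvegicus), read by thallium flux, with a stated time of 2.5 min (a higher number here means a larger maximal response, a lower number a smaller maximal response), compound 2 gives 34.8%, and compound 1 gives 67.6%. The two differ only by cyclopentyl in place of hydrogen on a saturated chain carbon bound to a carbonyl carbon, and the step of a number 32.8 percentage points higher from compound 2 to compound 1 (beyond the scatter) is the one large movement seen so far in this assay.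

Compound 3 gives 25.4% in this assay. Its core differs from the core of compound 2; the difference between the two cores is not broken down here. The values of compound 2 and compound 3 lie within the scatter of each other, so nothing is made of their order.

Compound 4, `Cc1cc(C(=O)O)ccc1OCCCCOc1ccc(C(=O)CC2CCCC2)c(O)c1C`, is not yet measured. It carries the core of compound 3 and differs from it by cyclopentyl in place of hydrogen on a saturated chain carbon bound to a carbonyl carbon. This is the same change as from compound 2 to compound 1, made at the same place. The expectation rests on one pair only, so it is held loosely: the step from compound 3 to compound 4 is estimated as a number 32.6 percentage points higher from compound 3 to compound 4 (beyond the scatter), in line with the step of a number 32.8 percentage points higher from compound 2 to compound 1 (beyond the scatter). On that basis compound 4 is expected to reach 58% in this assay, with a range from 40% to 76%.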

Compound 4, largest response reached (reported as percent of maximum), in percent of the reference or control that the assay uses: 28.4%
Compound 4: middle estimate off by 29.6 percentage points, on the high side, and the stated range ends above it.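

In this assay the cyclopentyl step does not carry from one core to the other, and the gap between the two steps lies beyond the scatter: the same change on two cores in this assay, a number 32.8 percentage points higher (beyond the scatter) from compound 2 to compound 1 and a number 3 percentage points higher (within the scatter) from compound 3 to compound 4, 29.8 percentage points apart, beyond the scatter of two such steps. On the core of compound 3, the step is a number 3 percentage points higher from compound 3 to compound 4 (within the scatter), so the added cyclopentyl leaves the response unchanged within the scatter there, while with the cyclopentyl kept in place, 4-carboxy-2-methylphenyl in place of 5-carboxy-2-methoxyphenyl gives a number 39.2 percentage points lower from compound 1 to compound 4 (beyond the scatter). This shows that, across these two pairs, the size of the step depends on the core, but it does not show which part of the difference between the two cores is responsible, nor how the step would behave on any further core.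

The compounds shown leave open whether the methoxy group or the placement of the carboxy group decides the outcome, which a core changed in only one of these two respects could separate. They also leave open whether a cyclohexyl group in place of the cyclopentyl, or an amide in place of the carboxylic acid, would follow the pattern of compound 1 or that of compound 4.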